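Swapping Phenyl for Thiophen-2-yl on a Tetrazole Inhibitor

The source may hold more compounds than are shown below. What is called first, only, known or untested is meant among the compounds shown, and "the series" means these compounds.

Compound 1 `CCCCCCCCc1ccc(OCC(=O)Cn2nnc(-c3cccc(S(=O)(=O)N(C)C)c3)n2)cc1` gives 420 nM in an assay on microsomes from brain for inhibition of Fatty-acid amide hydrolase 1 (Rattus norvegicus), read by fluorescence and HPLC, with a stated time of 60 min; a lower number here means a stronger inhibitor, a higher number a weaker inhibitor.
Compound 2 `CCCCCCCCc1ccc(OCC(=O)Cn2nnnc2-c2ccccc2)cc1` gives 71 nM in this assay.

Both compounds share the same core and were tested in this assay. Compound 2 stands at the lower of the two numbers, so it is the stronger inhibitor of the pair, and the gap to compound 1 lies beyond the usual scatter of repeated measurements. Nothing is known about which part of the difference between the two structures carries that gap.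

Compound 3 `CCCCCCCCc1ccc(OCC(=O)Cn2nnnc2-c2cccs2)cc1` has not yet been measured. It differs from compound 2 in one place: thiophen-2-yl in place of phenyl on an aromatic carbon. A five-membered aromatic ring taking the place of a six-membered one at the same position is a small change in size and shape, and the step is expected to be no larger than the scatter, as a 1.0-fold lower number from compound 2 to compound 3 (0.01 log units; within the scatter) shows. Compound 3 is therefore estimated at 70 nM, within a range from 30 nM to 170 nM.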

Compound 3, half-maximal inhibitory concentration: 55 nM
For compound 3 the middle estimate is 1.3-fold (0.10 log units) above the measured one; the range from low to high includes it.
By their numbers in this assay, from the lowest: compounds 3 and 2 (each within the scatter of the next); then compound 1.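

At this place on the shared core, on an aromatic carbon of a five-membered aromatic ring with 4 nitrogen, thiophen-2-yl and phenyl read alike in this assay, with a 1.3-fold lower number from compound 2 to compound 3 (0.11 log units; within the scatter). This position therefore accepts a five-membered aromatic ring holding a sulfur as well as a six-membered aromatic ring of carbon only, and the numbers show no gain or loss between the two. No measurement at hand explains why the two rings read alike.

The compounds shown are limited to aromatic rings at this position, so it remains open whether an amine, a carboxylic acid or a simple methyl group would be tolerated there. On these data alone, it also remains open whether a thiophen-3-yl group, attached through a different ring carbon, would read like thiophen-2-yl.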